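This account rests on a few compounds, and the source may have more. Where it says the series, first, only, none or still open, it means among the compounds named here.

Working notes on the series. In a functional assay, read by spectrophotometry, with a stated time of 5 min (a higher number here means a weaker inhibitor, a lower number a stronger inhibitor), compound 1 (`CCOc1cc(C=C(C(=O)/C=C/c2ccc(O)c(OCC)c2)C(=O)/C=C/c2ccc(O)c(OCC)c2)ccc1O`) gives 96700000 nM and compound 2 (`CCOc1cc(/C=C/C(=O)C(=Cc2ccc(O)cc2)C(=O)/C=C/c2ccc(O)c(OCC)c2)ccc1O`) gives 48000000 nM. Within the data shown here, these are the only two measured values, and they lie within the scatter of each other, so compound 2 cannot be separated from compound 1.

The next compound is compound 3 (`CCOc1cc(/C=C/C(=O)C(=Cc2ccc(O)c(O)c2)C(=O)/C=C/c2ccc(O)c(OCC)c2)ccc1O`), which changes compound 2 from 4-hydroxyphenyl to 3,4-dihydroxyphenyl: hydroxy in place of hydrogen on an aromatic carbon. This places hydroxy in place of hydrogen on an aromatic carbon, ortho to a hydroxy group.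

Among the measured compounds shown here, only one measured step bears on this change: a 2.0-fold lower number from compound 1 to compound 2 (0.30 log units; within the scatter), with hydrogen in place of ethoxy on an aromatic carbon. That step stays within the scatter, so swapping this substituent has not yet shown a measurable effect in this assay. For the measured compounds named here, no measured step introduces a hydroxy group, so the data give no direction for the change.

No shift beyond the scatter is therefore expected. The expected change is a 1.2-fold lower number from compound 2 to compound 3 (0.08 log units; within the scatter). For compound 3 the estimated value is 40000000 nM, with an expected range from 15000000 nM to 100000000 nM.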

Compound 3, half-maximal inhibitory concentration: 25200000 nM
Estimate against measurement, compound 3: 1.6-fold (0.20 log units) above; low and high end bracket the measured number.
By their numbers in this assay, from the lowest: compounds 3, 2 and 1 (each within the scatter of the next, the first and the last beyond it).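

In this assay, hydroxy in place of hydrogen on the aromatic carbon ortho to a hydroxy group gives a 1.9-fold lower number from compound 2 to compound 3 (0.28 log units; within the scatter), so this change alone, 4-hydroxyphenyl to 3,4-dihydroxyphenyl, has no measurable effect. Among these compounds, the wider step, a 3.8-fold lower number from compound 1 to compound 3 (0.58 log units; beyond the scatter), is the first to pass beyond the scatter: it reads as hydrogen in place of ethyl on an oxygen on an aromatic ring, a modest shift, whereas removing the ethoxy group outright gave only a 2.0-fold lower number from compound 1 to compound 2 (0.30 log units; within the scatter). No measurement is available that bears on the reason for this shift.

Going by these compounds, with a single compound carrying the free hydroxy at this position, it remains open whether the modest shift belongs to that group or would recur if the same change were made on the other aromatic rings of the core. A methoxy group or a longer chain on the same oxygen, or an amine or a carboxylic acid at this position, would show how far the numbers in this series follow the group at this place.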